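This account rests on a few compounds, and the source may have more. Where it says the series, first, only, none or still open, it means among the compounds named here.

Measured so far:
- Compound 1, `C/C(CC(=O)Nc1nnc(/C=C/c2ccccc2)s1)=N\c1ccccn1`: 4.23
- Compound 2, `C/C(CC(=O)Nc1nnc(-c2ccc(N)cc2)s1)=N\c1ccc([N+](=O)[O-])cn1`: 3.21
- Compound 3, `C/C(CC(=O)Nc1nnc(-c2ccc([N+](=O)[O-])cc2)s1)=N\c1ccccn1`: 3.63

These three compounds share one core and were measured in a physicochemical assay for lipophilicity, measured as octanol-water partition; on this read-out lower numbers stand for lower lipophilicity and higher numbers for higher lipophilicity. Among them compound 3 stands second highest: its nearest neighbour is compound 2, and the gap to compound 1 is the larger one. Among the compounds with values here, the single measured step between compounds that differ in one place is a number 0.60 log units lower from compound 1 to compound 3 (beyond the scatter), a modest fall.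

Compound 4, `C/C(CC(=O)Nc1nnc(-c2ccc(N)cc2)s1)=N\c1ccccn1`, has not yet been measured. It differs from compound 3 by amino in place of nitro on an aromatic carbon. Within the data shown here, no measured step shows this exchange directly; the step from compound 1 to compound 3 changed a different group and so gives only a rough sense of how large a change at this ring can be. The expectation therefore rests on the counted difference itself: a group of three heavy atoms with two acceptors leaves, a single-atom group with one donor enters, para to a large group. On that basis compound 4 is expected to come out lower than compound 3, by a step of about a number 0.68 log units lower from compound 3 to compound 4 (beyond the scatter), beyond the scatter. The estimate for compound 4 in this assay is 2.95, with a range from 2.5 to 3.4.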

Compound 4, partition coefficient: 3.3
Compound 4: the middle estimate sits 0.35 log units below what was measured, and the stated range covers the measured number.
By their numbers in this assay, from the lowest: compounds 2 and 4 (each within the scatter of the next); then compound 3; then compound 1.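

In this assay, the exchange of nitro for amino on an aromatic carbon, para to a large group, now has a measured size, a number 0.33 log units lower from compound 3 to compound 4 (beyond the scatter) and so is a real if modest change at this position. The 4-aminophenyl group can also be set directly against 2-phenylethenyl, with a number 0.93 log units lower from compound 1 to compound 4 (beyond the scatter) as the result, so this place in the molecule now has three measured groups instead of two. Compound 2 adds a contrast: the removal of its nitro group gives a number 0.09 log units higher from compound 2 to compound 4 (within the scatter) and therefore no measurable difference, while the nitro-to-amino exchange does give one, although these are different exchanges at different places and cannot separate the effect of the group from that of its position.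

From the compounds shown here alone, it remains open how a plain hydrogen, a methoxy group or a carboxylic acid at the para position of this phenyl ring would compare with amino and nitro, and whether the nitro-to-amino step would keep its size on a different core. Nothing available here explains why any of these numbers moved as they did.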